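Aryl urea series: chloro added to compound 1

The compounds below may be only part of what the source reports. "The series", "measured", "known", "first", "only" and "open" are said of these compounds alone.

Going by the values given here, compound 1 `Cc1cc(NC(=O)Nc2cccc(Cl)c2)c2ccccc2n1` is the only member of the series with a number in an ADME assay on HEK293 cells (Homo sapiens) for cytotoxicity, with a stated time of 72 h; a higher number here means that more compound is needed for the effect, a lower number that less compound is needed: compound 1 gives 21000 nM. Compound 2 `COc1cccc(NC(=O)Nc2cc(C)nc3ccccc23)c1` in this assay reports only a limit, > 25000 nM. Compound 3 `Cc1cc(NC(=O)Nc2ccccc2N)c2ccccc2n1` in this assay likewise reports only a limit, > 25000 nM. The steps of an at least 1.1-fold higher number from compound 1 to compound 2 (0.07 log units; that floor lies within the scatter) and an at least 1.1-fold higher number from compound 1 to compound 3 (0.07 log units; that floor lies within the scatter) are both floors that lie within the scatter, so neither known change on the aryl ring of compound 1 is shown to move the read-out beyond it; the series sits at the limit of > 25000 nM in this assay, at which 2 of the 3 values shown sit.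

Compound 4 `Cc1cc(NC(=O)Nc2ccc(Cl)c(Cl)c2)c2ccccc2n1` differs from compound 1 by chloro in place of hydrogen on an aromatic carbon. Both measured steps alter substituents on the same aryl ring and neither shows a step beyond the scatter, so for compound 4 no step beyond the scatter is expected in this assay either, and a limit rather than a number is quite possible. Compound 4 is expected at 18000 nM, between 8000 nM and 40000 nM. This corresponds to an expected step of a 1.2-fold lower number from compound 1 to compound 4 (0.07 log units; within the scatter).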

Compound 4, half-maximal effective concentration: > 25000 nM
Compound 4 was reported as a limit; the forecaster's own chance of this, stated with the estimate: 35%; at least 1.3-fold (0.14 log units) between middle value and limit.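

In this assay, chloro in place of hydrogen, ortho to a chloro group and para to a large group, gives an at least 1.1-fold higher number from compound 1 to compound 4 (0.07 log units; that floor lies within the scatter). Unlike the two earlier steps, which replace a group on the aryl ring, this change keeps the existing chloro and adds a second one, and the floor shows no step beyond the scatter. Compound 4 joins the compounds reported only as limits, so the series stays where it was: the limit of > 25000 nM in this assay, at which 3 of the 4 values shown sit.

As far as these compounds go, with a number for compound 1 alone, the true size of all three steps cannot be read, and whether any change on this ring moves the read-out beyond the scatter stays open. From the compounds shown here alone, how a carboxylic acid or a longer chain at this position would read in this assay also stays open.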